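The source may hold more compounds than are shown below. What is called first, only, known or untested is meant among the compounds shown, and "the series" means these compounds.

Measured compounds:
- compound 1 `COc1cc2c(cc1CC=C(C)C)C(=O)C[C@@H](c1ccc(Oc3cccc([N+](=O)[O-])c3)cc1)O2`, 53%
- compound 2 `COc1ccc([C@@H]2C/C(=N/OCc3cn(-c4ccc(O)cc4)nn3)c3cc(CC=C(C)C)c(OC)cc3O2)cc1`, 63%
- compound 3 `CC(C)=CCc1cc2c(cc1O)O[C@H](c1ccc(O)cc1)CC2=O`, 99%

In a functional assay on MCF7 cells (Homo sapiens) for inhibition, read by sulforhodamine B assay, with a stated time of 48 h, tested at 50 uM (a lower number here means less inhibition of growth, a higher number more inhibition of growth at the concentration tested), compound 1 gives the smallest of the three numbers; its gap to compound 2 lies within the usual scatter, while its gap to compound 3 lies well beyond it. Compound 4 `CCCOc1ccc([C@@H]2CC(=O)c3cc(CC=C(C)C)c(OC)cc3O2)cc1` shares the core of compound 1 and differs from it in one place: propyl in place of 3-nitrophenyl on an oxygen on an aromatic ring. Among the measured compounds shown here, no measured pair shows this change, so its effect in this assay cannot be read from a known step; compound 3 and compound 2 carry other changes. For compound 4 the step is expected to stay within the scatter, a number 2 percentage points higher from compound 1 to compound 4 (within the scatter), with no clear direction. Compound 4 is therefore estimated at 55%, in a range from 35% to 75%.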

Compound 4, percent growth inhibition at one concentration: 60%
Compound 4: the middle estimate sits 5 percentage points below what was measured; the measured number falls inside the stated range.
By their numbers in this assay, from the lowest: compounds 1, 4 and 2 (each within the scatter of the next); then compound 3.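

In this assay, propyl in place of 3-nitrophenyl on an oxygen on an aromatic ring gives a number 7 percentage points higher from compound 1 to compound 4 (within the scatter). This first pair to differ only at this position shows that the 3-nitrophenyl, with its aromatic ring and nitro group, is not required for growth inhibition at this level, since the smaller propyl serves about as well. Nothing measured here explains why the two groups are so close. From the compounds shown here alone, what a longer chain, a benzyl group, or a chain ending in an amine or a carboxylic acid would do on this oxygen remains open.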